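The source may report more compounds than this note shows. Statements on the series, on what has been measured and on what is new or still open speak of the compounds shown alone.

Measured compounds:

Compound 1 `CNc1ncnc2c1c(-c1cccs1)cn2[C@@H]1O[C@H](CO)[C@@H](O)[C@H]1O` — in a functional assay on HeLa S3 cells (Homo sapiens) for antiproliferative activity, read by XTT assay, with a stated time of 72 h (on this read-out higher numbers stand for weaker inhibition and lower numbers for stronger inhibition), compound 1 gives > 20000 nM, which is a limit of the assay rather than a number.

Compound 2 `Nc1nc2c(c(-c3ccco3)cn2[C@@H]2O[C@H](CO)[C@@H](O)[C@H]2O)c(=O)[nH]1` — in this assay compound 2 gives > 20000 nM, again a limit and not a number.

Compound 3 `O=c1[nH]cnc2c1c(-c1ccco1)cn2[C@@H]1O[C@H](CO)[C@@H](O)[C@H]1O` — in this assay compound 3 gives 5780 nM.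

Compound 2 thus stands only at a limit in this assay, and it is one of the two compounds sitting at the limit of > 20000 nM in this assay, at which 2 of the 3 values shown sit; no number is known for it. For the measured compounds named here, the single measured step, an at least 3.4-fold lower number from compound 2 to compound 3 (0.53 log units; beyond the scatter), concerns the removal of an amino group and does not touch the furan ring.

Compound 4 `Nc1nc2c(c(-c3ccoc3)cn2[C@@H]2O[C@H](CO)[C@@H](O)[C@H]2O)c(=O)[nH]1` differs from compound 2 by furan-3-yl in place of furan-2-yl on an aromatic carbon. Going by the values given here, no measured pair shows how swapping one furan attachment for the other affects this assay, so there is no basis for expecting a step beyond the scatter in either direction. Compound 4 is therefore expected, with little confidence, to remain near the limit; the step from compound 2 is estimated as a step that the limit leaves unreadable from compound 2 to compound 4. The estimate for compound 4 in this assay is 30000 nM, within a range from 8000 nM to 100000 nM.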

Compound 4, half-maximal inhibitory concentration: 10700 nM
Compound 4: middle estimate off by 2.8-fold (0.45 log units), on the high side; measured number inside the range.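

In this assay, furan-3-yl in place of furan-2-yl on the same aromatic carbon gives an at least 1.8-fold lower number from compound 2 to compound 4 (0.27 log units; that floor lies within the scatter), the first step shown that touches this position. Compound 4 has a number where compound 2 has only a limit, so changing the furan's point of attachment alone, with the same atoms, is enough to bring a readable value into reach, although the smallest step the data allow does not go beyond the scatter. The true size of the step cannot be read, because compound 2 remains at a limit: the limit of > 20000 nM in this assay, at which 2 of the 4 values shown sit.

Going by these compounds, whether the same furan change would matter on the core of compound 3, which lacks the amino group, stays open. So does how a phenyl ring or a plain methyl group would behave at this position.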